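Exchanging Chloro for Pyridin-3-yl: What to Expect

The source may report more compounds than this note shows. Statements on the series, on what has been measured and on what is new or still open speak of the compounds shown alone.

Among the compounds with values here, in an assay on CHO cells for antagonist activity at transient receptor potential cation channel subfamily V member 1 (Homo sapiens), read by FLIPR (on this read-out higher numbers stand for weaker inhibition and lower numbers for stronger inhibition), compound 2 `CC(C(=O)NCc1ccc(C(F)(F)F)cc1Cl)c1ccc(NS(C)(=O)=O)c(F)c1` gives 4 nM, the higher of the two numbers measured so far. Compound 1 `CCCCCCSc1cc(C(F)(F)F)ccc1CNC(=O)C(C)c1ccc(NS(C)(=O)=O)c(F)c1` gives 1.8 nM in this assay. Compound 3 `CC(C(=O)NCc1ccc(C(F)(F)F)cc1-c1cccnc1)c1ccc(NS(C)(=O)=O)c(F)c1` has not yet been measured; it differs from compound 2 in one place: pyridin-3-yl in place of chloro on an aromatic carbon. Within the data shown here, the only measured step, a 2.2-fold higher number from compound 1 to compound 2 (0.35 log units; beyond the scatter), changed the group on that same aromatic carbon, trading hexylsulfanyl for chloro. It gives only loose guidance, as pyridin-3-yl is a ring rather than a chain, so a step no larger than that one is expected, in either direction. Compound 3 is therefore estimated at 3 nM, between 0.8 nM and 12 nM, which means an expected step of a 1.3-fold lower number from compound 2 to compound 3 (0.12 log units; within the scatter).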

Compound 3, inhibition constant: 59.4 nM
The estimate for compound 3 lay 20-fold (1.30 log units) below the measured number; the measured number lies above the stated range.
By their numbers in this assay, from the lowest: compound 1; then compound 2; then compound 3.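

On this aromatic carbon, pyridin-3-yl gives a 15-fold higher number from compound 2 to compound 3 (1.17 log units; beyond the scatter) and, set against hexylsulfanyl, a 33-fold higher number from compound 1 to compound 3 (1.52 log units; beyond the scatter), where a higher number means weaker inhibition. The long hexylsulfanyl chain and the single chloro atom differ only modestly, so this ring is the first group shown here to cost much at this position. Nothing available explains this loss. Still open, on these data alone, is whether a phenyl ring, which lacks the ring nitrogen, would behave like pyridin-3-yl. Also open, as far as these compounds go, is how a shorter chain such as methylsulfanyl would compare with hexylsulfanyl.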